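Sulfonyl for Carbonyl on the Propylene Chain

This account rests on a few compounds, and the source may have more. Where it says the series, first, only, none or still open, it means among the compounds named here.

Compound 1, `O=S(=O)(NCCCNc1nccc(-c2c(-c3cccc(F)c3)nc3sccn23)n1)c1ccc(F)cc1`, gives 14500 nM in a functional assay on A-375 cells (Homo sapiens) for cytotoxicity, read by MTT assay; a lower number here means a stronger inhibitor, a higher number a weaker inhibitor. Compound 2, `O=C(NCCNc1nccc(-c2c(-c3cccc(F)c3)nc3sccn23)n1)c1ccc(Cl)cc1`, gives 2570 nM. Compound 3, `O=C(NCCCNc1nccc(-c2c(-c3cccc(F)c3)nc3sccn23)n1)c1ccc(Cl)cc1`, gives 13700 nM.

Compound 3 sits second highest of the three numbers; its nearest neighbour is compound 1, a difference that lies within the scatter, while a 5.3-fold higher number from compound 2 to compound 3 (0.73 log units; beyond the scatter) separates it from compound 2. Compound 4, `Cc1ccc(S(=O)(=O)NCCCNc2nccc(-c3c(-c4cccc(F)c4)nc4sccn34)n2)cc1`, differs from compound 3 by (4-methylphenyl)sulfonyl in place of (4-chlorophenyl)carbonyl on an amine nitrogen. Among the compounds with values here, the one measured step that bears directly on this change is a 1.1-fold lower number from compound 1 to compound 3 (0.02 log units; within the scatter), the same exchange between a sulfonyl and a carbonyl on the same amine nitrogen, which left the number essentially where it was. On that basis the reverse exchange in compound 4 is expected to move this assay by no more than the scatter, in no particular direction. Compound 4 is therefore estimated at 14000 nM, within 5500 nM to 36000 nM. The step from compound 3 that this estimate means is a 1.0-fold higher number from compound 3 to compound 4 (0.01 log units; within the scatter), expected to stay within the scatter.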

Compound 4, half-maximal inhibitory concentration: 8380 nM
The estimate for compound 4 lay 1.7-fold (0.22 log units) above the measured number, and the stated range covers the measured number.
By their numbers in this assay, from the lowest: compound 2; then compounds 4, 3 and 1 (each within the scatter of the next).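

In this assay, (4-methylphenyl)sulfonyl in place of (4-chlorophenyl)carbonyl on the amine nitrogen gives a 1.6-fold lower number from compound 3 to compound 4 (0.21 log units; within the scatter), so a second sulfonyl group also fails to separate from the carbonyl at this position. Methyl in place of fluoro on an aromatic carbon gives a 1.7-fold lower number from compound 1 to compound 4 (0.24 log units; within the scatter), which means this change on the sulfonyl group's ring also stays within the scatter. The step of a 3.3-fold higher number from compound 2 to compound 4 (0.51 log units; beyond the scatter) lies beyond the scatter, so the chain of compound 2 remains the one feature here tied to a clear difference.

Nothing available explains any of these steps. Still open, going by these compounds, are whether a sulfonyl group would hold up on the chain of compound 2, and whether an amine, a carboxylic acid or a longer chain would shift the number.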